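A few compounds are considered here, and "the series" means these few. Any claim that something is new, unique, unknown or untested is made for them only; others in the source may bear on it.

Values so far in this series, all from one read-out (a functional assay on MCF7 cells (Homo sapiens) for inhibition, read by MTT assay, with a stated time of 48 h; on this read-out lower numbers stand for stronger inhibition and higher numbers for weaker inhibition):
compound 1 (`CCOC(=O)C1=C(NN=C(C(C)=O)C(C)=O)Nc2[nH]nc(C)c2C1c1ccc(N(C)C)cc1`) gives 9740 nM 
compound 2 (`CCOC(=O)C1=C(NN=C(C#N)C#N)Nc2[nH]nc(C)c2C1c1ccc(N(C)C)cc1`) gives 12100 nM 
compound 3 (`CCOC(=O)C1=C(N/C=N/c2ccccn2)Nc2[nH]nc(C)c2C1c1ccc(N(C)C)cc1`) gives 37300 nM 

Compound 3 has the highest number of the three, and its steps to both others lie beyond the scatter, so it is the weakest of this small set. The move to compound 4 (`CCOC(=O)C1=C(N/N=C(/C(=O)Br)c2ccc(Cl)cc2)Nc2[nH]nc(C)c2C1c1ccc(N(C)C)cc1`) is a group of 12 heavy atoms (8 carbon, 1 nitrogen, 1 oxygen, 1 chlorine, 1 bromine; one six-membered aromatic ring of carbon only) in place of a group of 8 heavy atoms (6 carbon, 2 nitrogen; one six-membered aromatic ring with 1 hetero atom), on an amine nitrogen and removes the aromatic ring with a hetero atom. The entering group has a six-membered aromatic ring of carbon only, while the groups of compound 1 and compound 2 have no ring.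

Among the measured compounds shown here, two measured steps bear on this, and both run towards the group that leaves here: a 3.8-fold higher number from compound 1 to compound 3 (0.58 log units; beyond the scatter) and a 3.1-fold higher number from compound 2 to compound 3 (0.49 log units; beyond the scatter) (each modest). The remaining step of a 1.2-fold higher number from compound 1 to compound 2 (0.09 log units; within the scatter) lies within the scatter, which suggests that the two ringless groups do not separate. Read in reverse, the two modest steps point to a lower number on leaving compound 3. For the measured compounds named here, no measured compound carries chlorine or bromine, however, so the range has to stay wide.

The expected step in this assay is a 2.7-fold lower number from compound 3 to compound 4 (0.43 log units; beyond the scatter) (a modest move to a lower number, with no certainty of clearing the scatter). The estimate for compound 4 is 14000 nM (expected range 5000 nM to 38000 nM).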

Compound 4, half-maximal inhibitory concentration: 46300 nM
Beside the measured number, compound 4's estimate is 3.3-fold (0.52 log units) below it; the measured number lies above the stated range.
By their numbers in this assay, from the lowest: compounds 1 and 2 (each within the scatter of the next); then compounds 3 and 4 (each within the scatter of the next).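

Working notes: in this assay, the exchange at this amine nitrogen gives a 1.2-fold higher number from compound 3 to compound 4 (0.09 log units; within the scatter), so the larger group with its six-membered aromatic ring of carbon only, chlorine and bromine does not separate from the group with a six-membered aromatic ring with one hetero atom. Against the ringless groups, the same compound gives a 3.8-fold higher number from compound 2 to compound 4 (0.58 log units; beyond the scatter) and a 4.8-fold higher number from compound 1 to compound 4 (0.68 log units; beyond the scatter), which places both ring-bearing groups on the higher-number side of both ringless groups, a pattern that holds across these four compounds, with none going against it. Nothing in hand accounts for this split between ring-bearing and ringless groups.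

Still open, going by these compounds, is whether the aromatic ring itself goes with the higher numbers in this assay, or whether a saturated ring such as morpholine or piperidine on this amine nitrogen would fall with the ring-bearing groups or the ringless ones. Also open, on these data alone, is what the halogens contribute, a question that a plain phenyl group or a simple ethyl ester in place of the acid bromide carbonyl could address.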